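The source may report more compounds than this note shows. Statements on the series, on what has been measured and on what is new or still open speak of the compounds shown alone.

In a functional assay on HT-29 cells (Homo sapiens) for inhibition, read by sulforhodamine B assay, with a stated time of 48 h (a lower number here means a stronger inhibitor of growth, a higher number a weaker inhibitor of growth), two compounds of this small series have been measured so far. Compound 1 `CCOC(=O)c1nn(-c2ccccc2)c(-c2ccc(OC)cc2)c1CNC(C)(C)C` gives 61300 nM; 44200 nM (2 entries) across two entries. Compound 2 `CC(C)(C)NCc1c(C(=O)O)nn(-c2ccccc2)c1-c1ccccc1` is recorded only as > 716000 nM, which is a limit of the assay and not a number, and a further entry for it also gives no single number.

Compound 3 `COc1ccc(-c2c(CNC(C)(C)C)c(C(=O)O)nn2-c2ccccc2)cc1` comes from compound 2 by one change, methoxy in place of hydrogen on an aromatic carbon, para to a large group, so that phenyl becomes 4-methoxyphenyl: methoxy in place of hydrogen on an aromatic carbon. Among the compounds with values here, no two measured compounds differ in one place alone, so this assay gives no direct measure of this change. Within the data shown here, compound 1 is the only measured compound carrying 4-methoxyphenyl, but with its 61300 nM; 44200 nM (2 entries) it differs from compound 3 elsewhere too, so it offers weak guidance. Only a small shift towards stronger growth inhibition is expected, probably not clearly beyond the scatter. The expected step is an at least 1.4-fold lower number from compound 2 to compound 3 (0.15 log units; that floor lies within the scatter). For compound 3 the estimated value is 500000 nM, within an expected range of 200000 nM to 800000 nM.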

Compound 3, concentration for 50% growth inhibition: > 659000 nM
Compound 3: only a limit was reported (the forecaster's own chance of this, stated with the estimate: 65%); middle value at least 1.3-fold (0.11 log units) from the limit.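

In this assay, compound 3 is recorded only as > 659000 nM, which is a limit of the assay and not a number. Within the data shown here, compound 2 is likewise recorded only as a limit, > 716000 nM, so no step between compound 2 and compound 3 can be read. Going by these compounds, whether methoxy in place of hydrogen changes growth inhibition at all remains open.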